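The source may report more compounds than this note shows. Statements on the series, on what has been measured and on what is new or still open speak of the compounds shown alone.

Compound 1 `COc1ccc(C(=O)/C=C/c2ccc(N(C)C)cc2)c2c1C=CC(C)(C)O2` gives 730 nM in a functional assay on HepG2 cells (Homo sapiens) for antiproliferative activity, read by MTT assay, with a stated time of 24 h; a higher number here means a weaker inhibitor, a lower number a stronger inhibitor. Compound 3 `COc1ccc(C(=O)/C=C/c2ccc([N+](=O)[O-])cc2)c2c1C=CC(C)(C)O2`, which carries a nitro group in place of the dimethylamino group on an aromatic carbon, gives 2610 nM in this assay. For compound 2 `COc1ccc(C(=O)/C=C/c2ccc(-n3ccnc3)cc2)c2c1C=CC(C)(C)O2`, which carries a 1H-imidazol-1-yl group in place of the dimethylamino group on an aromatic carbon, this assay reports only a limit, > 10000 nM, so no number is known for it. Among the two numbers shown, compound 3 has the higher one: the step of a 3.6-fold higher number from compound 1 to compound 3 (0.55 log units; beyond the scatter) is modest, while the steps of an at least 13-fold higher number from compound 1 to compound 2 (1.13 log units; beyond the scatter) and an at least 3.8-fold lower number from compound 2 to compound 3 (0.58 log units; beyond the scatter) run to and from the limit of > 10000 nM in this assay, at which 1 of the 3 values shown sits, which is where compound 2 sits.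

Compound 4 `COc1ccc(C(=O)/C=C/c2ccc(C(F)(F)F)cc2)c2c1C=CC(C)(C)O2` differs from compound 3 in one place: trifluoromethyl in place of nitro on an aromatic carbon. For the measured compounds named here, no measured step involves a trifluoromethyl group, so the expectation rests on how far the numbers moved when the group on that aromatic carbon was exchanged among compounds 1, 2 and 3: from a modest change to one that is at least large. Against that spread, compound 4 is expected to stay in the weaker part of the range, with an expected step of a 1.1-fold higher number from compound 3 to compound 4 (0.06 log units; within the scatter) that may remain within the scatter. The estimate for compound 4 in this assay is 3000 nM, with a range from 900 nM to 10000 nM.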

Compound 4, half-maximal inhibitory concentration: > 10000 nM
Compound 4 ended at the assay's limit; the forecaster's own chance of this, stated with the estimate: 20%; at least 3.3-fold (0.52 log units) between middle value and limit.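

In this assay, this place on the aromatic ring, para to a large group, responds even to an exchange between two groups that carry no hydrogen-bond donors and no net charge, as an at least 3.8-fold higher number from compound 3 to compound 4 (0.58 log units; beyond the scatter) shows. The dimethylamino group of compound 1 still gives the lowest number of the series, and the new group sits far from it, with an at least 13-fold higher number from compound 1 to compound 4 (1.13 log units; beyond the scatter). Compound 4 gives a limit of the assay rather than a number, as compound 2 does, so the step between these two cannot be read, and a second group at this place now ends up there: the limit of > 10000 nM in this assay, at which 2 of the 4 values shown sit.

The compounds shown leave open whether the low number of compound 1 belongs to dimethylamino alone, or whether a plain amine, a diethylamino group or a hydroxyl group at this place would give a similar result. They also leave open what numbers lie behind the limits of compound 2 and compound 4, and whether the trifluoromethyl group and the nitro group would keep their order on another carbon of the ring.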